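Side-group exchange from compound 2 to compound 3

The source may report more compounds than this note shows. Statements on the series, on what has been measured and on what is new or still open speak of the compounds shown alone.

Compound 1 (`c1ccc(-c2nc3ccn(CC4CCCCC4)cc-3n2)cc1`) carries cyclohexyl on the saturated chain carbon bound to an aromatic nitrogen. In an ADME assay on MDBK cells (Bos taurus) for cytotoxicity (a higher number here means that more compound is tolerated, a lower number that less compound is tolerated), compound 1 gives > 100000 nM as a limit of the assay and not a number. Compound 2 (`c1ccc(-c2nc3ccn(Cc4ccncc4)cc-3n2)cc1`) carries pyridin-4-yl in that place. In this assay compound 2 gives > 100000 nM as a limit too, so it has no exact standing on the numbers. The record so far is the limit of > 100000 nM in this assay, at which 2 of the 2 values shown sit, and no measured number lies under it.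

Compound 3 (`Clc1ccc(Cn2ccc3nc(-c4ccccc4)nc-3c2)s1`) has 5-chlorothiophen-2-yl in place of pyridin-4-yl, and the counted difference reads 5-chlorothiophen-2-yl in place of pyridin-4-yl on a saturated chain carbon bound to an aromatic nitrogen on that same carbon. Within the data shown here, the only measured step bearing on this exchange is a step that the two limits leave unreadable from compound 1 to compound 2 and it supplies no size to carry over. A small move toward less compound tolerated is therefore expected, and compound 3 may well report only a limit. The estimated change is an at least 1.2-fold lower number from compound 2 to compound 3 (0.09 log units; that floor lies within the scatter) and it remains a cautious expectation. For compound 3 the estimated value is 80000 nM with an expected range from 25000 nM to 100000 nM as the working figure.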

Compound 3, half-maximal cytotoxic concentration: > 100000 nM
Compound 3: a limit, no number; the forecaster's own chance of this, stated with the estimate: 55%; at least 1.2-fold (0.09 log units) between middle value and limit.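

In this assay compound 3 gives > 100000 nM as a limit of the assay and not a number. Among these compounds, compound 1, compound 2 and compound 3 all sit at a limit, and no step among them can be read. Still open is whether cyclohexyl, pyridin-4-yl and 5-chlorothiophen-2-yl differ at all in this read-out, and at what concentration any of these compounds stops being tolerated.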